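A few compounds are considered here, and "the series" means these few. Any claim that something is new, unique, unknown or untested is made for them only; others in the source may bear on it.

Working notes on the series, read in an ADME assay on liver for metabolic stability, with Liver microsome (Homo sapiens) as the target, using microsomes; a lower number here means slower removal, a higher number faster removal of the compound. Compound 1 `CC(=O)Nc1cccc(Nc2cc(NC3CC3)n3ncc(C#N)c3n2)c1` gives 20 mL.min-1.g-1 and compound 2 `CCN(CC)CCN(C)c1ccc(Nc2cc(NC3CC3)n3ncc(C#N)c3n2)cc1NC(C)=O` gives 44 mL.min-1.g-1, so compound 2 holds the higher of the two numbers. The next structure is compound 3 `CC(=O)Nc1cc(Nc2cc(NC3CC3)n3ncc(C#N)c3n2)ccc1NCCCO`, with (3-hydroxypropyl)amino in place of (2-(diethylamino)ethyl)(methyl)amino on an aromatic carbon, ortho to an acetamido group: (3-hydroxypropyl)amino in place of (2-(diethylamino)ethyl)(methyl)amino on an aromatic carbon. Within the data shown here, only one measured step bears on this change: a 2.2-fold higher number from compound 1 to compound 2 (0.34 log units; beyond the scatter), seen when the group that now leaves replaced hydrogen. That step is modest, and compound 3 still carries a chain at this place, so only part of it is expected to reverse. A small move to a lower number is expected, possibly not beyond the scatter. The expected step is a 1.5-fold lower number from compound 2 to compound 3 (0.17 log units; within the scatter). For compound 3 the estimated value is 30 mL.min-1.g-1, with an expected range of 15 mL.min-1.g-1 to 60 mL.min-1.g-1.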

Compound 3, intrinsic clearance in microsomes: 21 mL.min-1.g-1
Estimate against measurement, compound 3: 1.4-fold (0.15 log units) above; the measured number falls inside the stated range.
By their numbers in this assay, from the lowest: compounds 1 and 3 (each within the scatter of the next); then compound 2.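

In this assay, among these compounds, replacing (2-(diethylamino)ethyl)(methyl)amino with (3-hydroxypropyl)amino gives a 2.1-fold lower number from compound 2 to compound 3 (0.32 log units; beyond the scatter), the first reading of one chain against another at this position. Against the hydrogen of the unsubstituted parent, (3-hydroxypropyl)amino gives a 1.1-fold higher number from compound 1 to compound 3 (0.02 log units; within the scatter), so among the compounds shown, a chain at this position does not by itself go with a higher number; compound 2 is the only one that stands apart. No measured information bearing on the reason for these steps is available.

The compounds shown leave open which feature of the (2-(diethylamino)ethyl)(methyl)amino group goes with its higher number. A plain propylamino group and a (3-(diethylamino)propyl)amino group would help separate the roles of the hydroxyl and the diethylamino end.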